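The compounds below may be only part of what the source reports. "The series", "measured", "known", "first", "only" and "open" are said of these compounds alone.

Measured compounds:
compound 1 `O=C(/C=C/C(=O)N1C/C(=C\c2ccccc2)C(=O)/C(=C/c2ccccc2)C1)Nc1ccc(Cl)c(Cl)c1` — 350 nM
compound 2 `O=C(/C=C/C(=O)N1C/C(=C\c2ccccc2)C(=O)/C(=C/c2ccccc2)C1)Nc1ccccc1` — 1100 nM
compound 3 `Cc1ccc(NC(=O)/C=C/C(=O)N2C/C(=C\c3ccccc3)C(=O)/C(=C/c3ccccc3)C2)cc1` — 1100 nM

In a functional assay on CCRF-CEM cells (Homo sapiens) for cytotoxicity (on this read-out higher numbers stand for weaker inhibition and lower numbers for stronger inhibition), compound 3 gives 1100 nM, level with compound 2, and the two together stand at the highest of the three numbers; compound 1 sits apart, a 3.1-fold higher number from compound 1 to compound 3 (0.50 log units; beyond the scatter). Compound 4 `CC(=O)c1ccc(NC(=O)/C=C/C(=O)N2C/C(=C\c3ccccc3)C(=O)/C(=C/c3ccccc3)C2)cc1` is not yet measured and differs from compound 3 only on the ring carried by the amide-type nitrogen: acetyl in place of methyl on an aromatic carbon.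

The steps that speak to such a change are all on that same ring. Going from compound 1 to compound 2 or to compound 3 moves the number by a 3.1-fold higher number from compound 1 to compound 2 (0.50 log units; beyond the scatter) and a 3.1-fold higher number from compound 1 to compound 3 (0.50 log units; beyond the scatter), while no change at the digits printed from compound 2 to compound 3 (within the scatter) shows that the methyl itself is of no consequence. Among the compounds with values here, no measured compound carries an acetyl or any other group with an acceptor on that ring, so the direction is open; the measured steps suggest a change of modest size at most.

Compound 4 is therefore expected to give about 900 nM in this assay, within 400 nM to 2500 nM, which would mean a 1.2-fold lower number from compound 3 to compound 4 (0.09 log units; within the scatter).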

Compound 4, half-maximal inhibitory concentration: 1700 nM
The estimate for compound 4 lay 1.9-fold (0.28 log units) below the measured number, within the range that was stated.
By their numbers in this assay, from the lowest: compound 1; then compounds 2, 3 and 4 (each within the scatter of the next).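

In this assay, the acetyl on this aromatic carbon, para to a large group, does not separate compound 4 from the compounds carrying methyl or hydrogen there: a 1.5-fold higher number from compound 3 to compound 4 (0.19 log units; within the scatter) and a 1.5-fold higher number from compound 2 to compound 4 (0.19 log units; within the scatter). Within the data shown here, this extends the flat stretch of the series to a group with a hydrogen-bond acceptor and more heavy atoms than methyl, a kind of group absent from the earlier compounds on this ring. The 3,4-dichlorophenyl remains the only ring here that stands apart, with a 4.9-fold higher number from compound 1 to compound 4 (0.69 log units; beyond the scatter), so compound 1 keeps the lowest number of the four, and nothing available gives a reason for these numbers.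

The compounds shown leave open whether a single chlorine on this ring would account for the lower number of compound 1 or whether both chlorines are needed. They also leave open how an amine, a carboxylic acid or a longer acyl chain in the place of the acetyl would read out, so the flat stretch is established only for hydrogen, methyl and acetyl.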